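The source may report more compounds than this note shows. Statements on the series, on what has been measured and on what is new or still open speak of the compounds shown alone.

Measured compounds:
Compound 1 `Nc1ccc(S(=O)(=O)N2CCN(c3ncc(C(O)(C(F)(F)F)C(F)(F)F)cc3-c3ccoc3)CC2)cn1`: 57 mL.min-1.g-1
Compound 2 `Cc1csc(-c2cc(C(O)(C(F)(F)F)C(F)(F)F)cnc2N2CCN(S(=O)(=O)c3ccc(N)nc3)CC2)c1`: 399 mL.min-1.g-1
Compound 3 `CS(=O)(=O)c1ccc(-c2cc(C(O)(C(F)(F)F)C(F)(F)F)cnc2N2CCN(S(=O)(=O)c3ccc(N)nc3)CC2)cc1`: 103 mL.min-1.g-1

In an ADME assay (liver) for metabolic stability, with Liver microsome (Rattus norvegicus) as the target, using microsomes and NADPH, with a stated time of 30 min, tested at 1 uM (on this read-out lower numbers stand for slow clearance and higher numbers for fast clearance), compound 3 holds the second highest of the three numbers. Its nearest neighbour is compound 1, and the step of a 1.8-fold higher number from compound 1 to compound 3 (0.26 log units; within the scatter) lies within the scatter, so the two cannot be told apart. Its furthest neighbour is compound 2, and the step of a 3.9-fold lower number from compound 2 to compound 3 (0.59 log units; beyond the scatter) is a modest one beyond the scatter.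

Compound 4 `Nc1ccc(S(=O)(=O)N2CCN(c3ncc(C(O)(C(F)(F)F)C(F)(F)F)cc3-c3ccc4[nH]ncc4c3)CC2)cn1` has not been measured in this assay. It differs from compound 3 in one place: 1H-indazol-5-yl in place of 4-(methylsulfonyl)phenyl on an aromatic carbon. All three measured steps change the group on this same aromatic carbon, ortho to a large group and meta to the 2,2,2-trifluoro-1-hydroxy-1-(trifluoromethyl)ethyl group: a 7.0-fold higher number from compound 1 to compound 2 (0.85 log units; beyond the scatter), a 1.8-fold higher number from compound 1 to compound 3 (0.26 log units; within the scatter) and a 3.9-fold lower number from compound 2 to compound 3 (0.59 log units; beyond the scatter). None of them involves an 1H-indazol-5-yl group, so the data give only the spread of numbers this position has produced, from compound 1 to compound 2. Within that spread compound 3 sits in the lower half, and the step of a 1.3-fold lower number from compound 3 to compound 4 (0.11 log units; within the scatter) is therefore expected to stay within the scatter. Compound 4 is estimated to give 80 mL.min-1.g-1 in this assay, with a range from 30 mL.min-1.g-1 to 220 mL.min-1.g-1.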

Compound 4, intrinsic clearance in microsomes: 88 mL.min-1.g-1
Compound 4: the middle estimate sits 1.1-fold (0.04 log units) below what was measured, within the range that was stated.
By their numbers in this assay, from the lowest: compounds 1, 4 and 3 (each within the scatter of the next); then compound 2.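

Across the three groups now read at this aromatic carbon, the 1H-indazol-5-yl group gives a number in this assay that cannot be told apart from those of the two nearest compounds, with a 1.2-fold lower number from compound 3 to compound 4 (0.07 log units; within the scatter) and a 1.5-fold higher number from compound 1 to compound 4 (0.19 log units; within the scatter) both printed as within the scatter. The position therefore accepts a group with a five-membered and a six-membered aromatic ring and a hydrogen-bond donor without leaving the level of the furan-3-yl and 4-(methylsulfonyl)phenyl groups, while compound 2 goes against this grouping, as a 4.5-fold lower number from compound 2 to compound 4 (0.66 log units; beyond the scatter) shows, leaving the 4-methylthiophen-2-yl group alone at the high end among these four compounds. No measurement shown here accounts for the separation of compound 2 from the other three.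

The compounds shown leave open whether the high number of compound 2 follows from the thiophene ring itself or from its methyl group, which an unsubstituted thiophen-2-yl group at the same carbon would help to separate. They also leave open how a plain phenyl group, or a pyridinyl group, would read at this position in this assay when set against the groups already compared.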